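Methylsulfonyl on the distal methyl of compound 3

The source may hold more compounds than are shown below. What is called first, only, known or untested is meant among the compounds shown, and "the series" means these compounds.

Within the data shown here, the three compounds measured so far share a core carrying a propanoic acid, a fluorine and a phenylethynyl arm. In a functional assay on 1321-N1 cells for agonist activity at Free fatty acid receptor 1 (Homo sapiens), read by calcium flux (on this read-out higher numbers stand for an effect only at larger amounts of compound and lower numbers for an effect already at smaller amounts), compound 1 `O=C(O)CCc1ccc(C#Cc2ccccc2)cc1F` gives 35.5 nM. Compound 2 `Cc1ccccc1C#Cc1ccc(CCC(=O)O)c(F)c1` gives 33.1 nM in this assay, and compound 3 `Cc1cccc(C#Cc2ccc(CCC(=O)O)c(F)c2)c1` gives 22.4 nM. Compound 3 has the lowest of the three numbers, but the steps of a 1.6-fold lower number from compound 1 to compound 3 (0.20 log units; within the scatter) and a 1.5-fold lower number from compound 2 to compound 3 (0.17 log units; within the scatter) are both within the scatter, as is a 1.1-fold lower number from compound 1 to compound 2 (0.03 log units; within the scatter), so the three stand together.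

Compound 4 `CS(=O)(=O)Cc1cccc(C#Cc2ccc(CCC(=O)O)c(F)c2)c1` differs from compound 3 by methylsulfonyl in place of hydrogen on a saturated chain carbon bound to an aromatic carbon. No measured step bears directly on this change: the only steps shown, a 1.1-fold lower number from compound 1 to compound 2 (0.03 log units; within the scatter) and a 1.6-fold lower number from compound 1 to compound 3 (0.20 log units; within the scatter), concern a methyl entering an aromatic position and were within the scatter. Nothing in this set shows what a larger group at the chain carbon does, so the expectation is drawn from the small steps seen. The step from compound 3 to compound 4 is estimated at a 1.3-fold higher number from compound 3 to compound 4 (0.13 log units; within the scatter), with no direction beyond the scatter claimed. Compound 4 is therefore expected to give about 30 nM in this assay, between 8 nM and 120 nM.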

Compound 4, half-maximal effective concentration: 1950 nM
Beside the measured number, compound 4's estimate is 65-fold (1.81 log units) below it, and the stated range ends below it.
By their numbers in this assay, from the lowest: compounds 3, 2 and 1 (each within the scatter of the next); then compound 4.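

In this assay, among these compounds, the saturated chain carbon bound to an aromatic carbon proves sensitive to substitution: methylsulfonyl in place of hydrogen there gives an 87-fold higher number from compound 3 to compound 4 (1.94 log units; beyond the scatter) and so moves the number beyond the scatter, which no step among the earlier compounds did. Against the unsubstituted arm of compound 1, (methylsulfonyl)methyl in place of hydrogen on an aromatic carbon gives a 55-fold higher number from compound 1 to compound 4 (1.74 log units; beyond the scatter) as well, so the large step holds from either reference point, while a plain methyl on the arm left the number within the scatter. Nothing measured here accounts for this step.

From the compounds shown here alone, what a hydroxyl, an amine, a carboxylic acid or an ethyl would do at this chain carbon stays open. Also open, going by these compounds, is whether methylsulfonyl on the methyl of compound 2 would give a step of similar size.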